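This account rests on a few compounds, and the source may have more. Where it says the series, first, only, none or still open, it means among the compounds named here.

Measured compounds in an assay on CHO cells for displacement of a labelled ligand from prostaglandin E2 receptor EP2 subtype (Mus musculus), read by scintillation counting, with a stated time of 60 min; a higher number here means a weaker inhibitor, a lower number a stronger inhibitor:
- compound 1 `O=C(O)CCCSCCN1C(=O)OC[C@@H]1/C=C/[C@@H](O)Cc1ccccc1` gives > 10000 nM, which is a limit of this assay.
- compound 2 `O=C(O)CCCSCCN1C(=O)OC[C@@H]1/C=C/[C@@H](O)Cc1cccc(-c2ccccc2)c1` gives > 10000 nM, again a limit and not a number.

Compound 2 thus stands only at a limit of this assay; of the two values shown, both sit at that same limit, as noted in the limit of > 10000 nM in this assay, at which 2 of the 2 values shown sit. The step from compound 1 to compound 2, a step that the two limits leave unreadable from compound 1 to compound 2, is therefore not readable in size or direction, since both ends are limits.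

Compound 3 `CCc1cccc(C[C@H](O)/C=C/[C@H]2COC(=O)N2CCSCCCC(=O)O)c1` is not yet measured. It differs from compound 2 by ethyl in place of phenyl on an aromatic carbon; the group enters on an aromatic carbon of a six-membered aromatic ring of carbon only, meta to a large group. For the measured compounds named here, the only measured step that bears on this position, a step that the two limits leave unreadable from compound 1 to compound 2, shows no readable size, so no direction for the change from compound 2 to compound 3 can be taken from the data in this assay.

Compound 3 is therefore expected to sit at or near the same limit, with an estimate of 20000 nM (range 7000 nM to 100000 nM), which would mean an expected step that the limit leaves unreadable from compound 2 to compound 3 that cannot be separated from the scatter.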

Compound 3, inhibition constant: > 10000 nM
Compound 3: a limit, no number (the forecaster's own chance of this, stated with the estimate: 85%); the middle value is on the limit's open side.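

In this assay compound 3 gives > 10000 nM, a limit and not a number. No step among compound 1, compound 2 and compound 3 can be read in size or direction, as all three stand at the same limit: the limit of > 10000 nM in this assay, at which 3 of the 3 values shown sit. The compounds shown leave open whether any group on this aromatic carbon gives a measurable inhibition constant in this assay.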